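This account rests on a few compounds, and the source may have more. Where it says the series, first, only, none or still open, it means among the compounds named here.

Measured so far in an assay on membranes from brain for binding affinity to Neuronal acetylcholine receptor; alpha4/beta2 (Rattus norvegicus); a lower number here means a stronger inhibitor, a higher number a weaker inhibitor:
compound 1 `CN1CCC[C@H]1COc1cncc(-c2ccccc2)c1` — 0.11 nM
compound 2 `CN1CCC[C@H]1COc1cncc(-c2ccc(C(F)(F)F)cc2)c1` — 0.15 nM
compound 3 `CN1CCC[C@H]1COc1cncc(-c2cc3ccccc3n2C)c1` — 0.32 nM

Compound 1 gives the lowest of the three numbers; compound 2 sits a short way off, by a 1.4-fold higher number from compound 1 to compound 2 (0.13 log units; within the scatter), which is within the scatter, so no order between compound 1 and compound 2 can be read. Compound 3 is the furthest, with a number beyond the scatter of that of compound 1.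

Compound 4 `CN1CCC[C@H]1COc1cncc(-c2cccnc2)c1` has not yet been measured. It differs from compound 1 by pyridin-3-yl in place of phenyl on an aromatic carbon.

Within the data shown here, only one measured step bears on a change at this aromatic carbon, namely the step from compound 1 to compound 2, where trifluoromethyl in place of hydrogen on the phenyl gave a 1.4-fold higher number from compound 1 to compound 2 (0.13 log units; within the scatter), within the scatter. Among the measured compounds shown here, no measured pair exchanges the phenyl itself for another six-membered ring, so there is no direct precedent for the pyridin-3-yl in this assay. Given that the one nearby change left the number where it was, compound 4 is expected to stay close to compound 1, at most a small step up: the expected step from compound 1 to compound 4 is a 1.8-fold higher number from compound 1 to compound 4 (0.26 log units; within the scatter). Compound 4 is therefore estimated at 0.2 nM, with a range from 0.06 nM to 0.7 nM.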

Compound 4, inhibition constant: 0.27 nM
Compound 4: the middle estimate sits 1.4-fold (0.13 log units) below what was measured; low and high end bracket the measured number.
By their numbers in this assay, from the lowest: compounds 1, 2, 4 and 3 (each within the scatter of the next, the first and the last beyond it).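

In this assay, replacing the phenyl itself with pyridin-3-yl gives a 2.5-fold higher number from compound 1 to compound 4 (0.39 log units; beyond the scatter), so this aromatic carbon now has a step that can be read beyond the scatter, though a modest one. Among these compounds, the only earlier change here, trifluoromethyl on the phenyl, stayed within the scatter at a 1.4-fold higher number from compound 1 to compound 2 (0.13 log units; within the scatter), so the series now shows that exchanging one ring carbon for nitrogen, with one hydrogen-bond acceptor counted in the entering group, is enough to move the number, while compound 4 still holds 0.27 nM in this assay. The data offer no measurement that accounts for this step.

From the compounds shown here alone, with one aza exchange on record, it remains open whether the step belongs to the ring nitrogen as such or to where it sits, which a pyridin-4-yl or a pyrimidin-5-yl group at the same carbon would test. Also open, going by these compounds, is how this carbon responds to a saturated ring such as cyclohexyl, and whether an amine or a carboxylic acid on the phenyl would stay as close to compound 1 as trifluoromethyl does.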